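The compounds below may be only part of what the source reports. "The series", "measured", "known", "first", "only" and "open" are said of these compounds alone.

Values in an assay on CHO cells for displacement of a labelled ligand from histamine receptor H3 (Macaca mulatta); on this read-out lower numbers stand for stronger inhibition and higher numbers for weaker inhibition:
compound 1 `CC(=O)N1CCCC1C(=O)Nc1ccc(N2CCC(N3CCCC3C)C2)c(C)c1`: 44.9 nM
compound 2 `Cc1cc(NC(=O)C2C(C)(C)C2(C)C)ccc1N1CCC(N2CCCC2C)C1`: 65.5 nM

Compound 2 stands at the higher of the two numbers in this assay, with compound 1 as its nearest neighbour, and the step of a 1.5-fold higher number from compound 1 to compound 2 (0.16 log units; within the scatter) is within the scatter, so the two compounds are not distinguished by this read-out. Compound 3 `Cc1cc(NC(=O)C2CC3CCC2C3)ccc1N1CCC(N2CCCC2C)C1` is not yet measured. It differs from compound 2 by a group of 7 heavy atoms (7 carbon; 2 five-membered non-aromatic rings of carbon only) in place of a group of 7 heavy atoms (7 carbon; one three-membered non-aromatic ring of carbon only), on a carbonyl carbon.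

Among the measured compounds shown here, only one measured step bears on this change: a 1.5-fold higher number from compound 1 to compound 2 (0.16 log units; within the scatter). It exchanges the group on the same carbonyl carbon of the shared core and shows no movement beyond the scatter. The change to compound 3 again keeps the number of heavy atoms on that carbonyl carbon, with no donors or acceptors leaving or entering. On this basis the step from compound 2 to compound 3 is expected to stay within the scatter, in no firm direction, estimated as a 1.1-fold lower number from compound 2 to compound 3 (0.04 log units; within the scatter). Compound 3 is therefore expected to give about 60 nM in this assay, with a range from 25 nM to 150 nM.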

Compound 3, inhibition constant: 130 nM
For compound 3 the middle estimate is 2.2-fold (0.34 log units) below the measured one, within the range that was stated.
By their numbers in this assay, from the lowest: compounds 1, 2 and 3 (each within the scatter of the next, the first and the last beyond it).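

In this assay, placing the group with 2 five-membered non-aromatic rings of carbon only on the carbonyl carbon in place of 2,2,3,3-tetramethylcyclopropyl gives a step that stays within the scatter (a 2.0-fold higher number from compound 2 to compound 3 (0.30 log units; within the scatter)), so this read-out does not separate these two all-carbon groups of equal heavy-atom count. Among the compounds shown here, the first step beyond the scatter at this position is the modest one that replaces 1-acetylpyrrolidin-2-yl with the same two-ring group (a 2.9-fold higher number from compound 1 to compound 3 (0.46 log units; beyond the scatter)), while compound 2, with its own all-carbon group, lies within the scatter of both other compounds. No measurement at hand accounts for this step.

For the compounds shown here, with only three groups compared, the shift beyond the scatter cannot be tied to the nitrogen and oxygen of 1-acetylpyrrolidin-2-yl or to any other feature of that group. Still open, going by these compounds, is how the number moves with other groups on this carbonyl carbon, such as a primary amine, a carboxylic acid, a phenyl ring or a longer open alkyl chain.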